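A few compounds are considered here, and "the series" means these few. Any claim that something is new, unique, unknown or untested is made for them only; others in the source may bear on it.

Measured compounds:
compound 1, `COCC1(COC)Oc2ccc(C#N)cc2[C@@H](N=C(NC#N)c2cccnc2)[C@@H]1O`, 0.0467 h
compound 2, `COCC1(COC)Oc2ccc(C#N)cc2[C@@H](Nc2ccc(=O)n(C)n2)[C@@H]1O`, 0.0533 h
compound 3, `COCC1(COC)Oc2ccc(Br)cc2[C@@H](Nc2ccc(=O)n(C)n2)[C@@H]1O`, 0.0583 h

The read-out is an ADME assay on the whole organism (blood) for pharmacokinetics, with Canis familiaris (Canis lupus familiaris) as the target; on this read-out lower numbers stand for a shorter-lived compound and higher numbers for a longer-lived compound. In this assay compound 1 gives 0.0467 h, compound 2 gives 0.0533 h and compound 3 gives 0.0583 h. All three numbers sit within the usual scatter of one another, so nothing separates them.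

The difference between the core of compound 1 and the core of compound 2 is not broken down here. Compound 2 and compound 3 share a core and differ by bromo in place of cyano on an aromatic carbon. This change gives a 1.1-fold higher number from compound 2 to compound 3 (0.04 log units; within the scatter).

Compound 4, `COCC1(COC)Oc2ccc(Br)cc2[C@@H](N=C(NC#N)c2cccnc2)[C@@H]1O`, has not yet been measured in this assay. It differs from compound 1 by bromo in place of cyano on an aromatic carbon. The place of the change is described in the same words as for the pair of compound 2 and compound 3, so it is the same change on a different core.

For compound 4 the expected step is a 1.1-fold higher number from compound 1 to compound 4 (0.05 log units; within the scatter), resting on the earlier pair, because a 1.1-fold higher number from compound 2 to compound 3 (0.04 log units; within the scatter) stayed within the scatter. Compound 4 is therefore estimated at 0.052 h, with a likely range from 0.03 h to 0.09 h.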

Compound 4, half-life: 0.0167 h
The estimate for compound 4 lay 3.1-fold (0.49 log units) above the measured number, outside the stated range (below it).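

In this assay, bromo in place of cyano on an aromatic carbon gives a 2.8-fold lower number from compound 1 to compound 4 (0.45 log units; beyond the scatter), and this step does not match the one seen for the same change on the other core: the same change on two cores in this assay, a 1.1-fold higher number (0.04 log units; within the scatter) from compound 2 to compound 3 and a 2.8-fold lower number (0.45 log units; beyond the scatter) from compound 1 to compound 4, 3.1-fold (0.49 log units) apart, beyond the scatter of two such steps. In this series, then, the step read on the core of compound 2 did not carry over to the core of compound 1, and the size and direction of this change have to be read core by core. Among the compounds shown here, the two pairs do not show which feature of the cores accounts for the gap, nor how the change would behave on any further core, and each step rests on only one pair of compounds.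

The compounds shown leave open whether chloro or methoxy in the same place would give a step like that on the core of compound 1 or like that on the core of compound 2. Also open is whether a core carrying an amine in place of the groups shown would follow either pair.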